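From compound 2 to compound 3: exchanging one aromatic group

The compounds below may be only part of what the source reports. "The series", "measured", "known", "first", "only" and "open" are said of these compounds alone.

In a physicochemical assay for solubility, read by LC-MS, in phosphate buffer, with a stated time of 24 h, at pH 7.4 (on this read-out lower numbers stand for lower solubility and higher numbers for higher solubility), compound 1 `Cn1nccc1-c1cnc(NCc2c(F)ccc3c2CCO3)c2cn[nH]c(=O)c12` gives 2000 nM, and compound 2 `Cc1cc(-c2cnc(NCc3c(F)ccc4c3CCO4)c3cn[nH]c(=O)c23)n(C)n1` gives 1000 nM. Compound 2 thus stands within the scatter of compound 1. Going by the values given here, the only measured step is a 2.0-fold lower number from compound 1 to compound 2 (0.30 log units; within the scatter), with methyl in place of hydrogen on an aromatic carbon. Compound 3 `CNC(=O)c1ccc(-c2cnc(NCc3c(F)ccc4c3CCO4)c3cn[nH]c(=O)c23)c(C)n1` has not yet been measured. In it, 2-methyl-6-(methylcarbamoyl)pyridin-3-yl stands in place of 1,3-dimethyl-1H-pyrazol-5-yl on an aromatic carbon of the shared core: 2-methyl-6-(methylcarbamoyl)pyridin-3-yl in place of 1,3-dimethyl-1H-pyrazol-5-yl on an aromatic carbon. The measured step bears on this change only weakly, as it exchanges a single methyl and not the whole group. Among the compounds with values here, no measured compound shows what such an exchange does, so no direction can be argued from the data. The expected result is no step beyond the scatter: no change at the digits printed from compound 2 to compound 3 (within the scatter). For compound 3 the estimated value is 1000 nM, with an expected range from 300 nM to 3000 nM.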

Compound 3, solubility: 19000 nM
The estimate for compound 3 lay 19-fold (1.28 log units) below the measured number, and the stated range ends below it.
By their numbers in this assay, from the lowest: compounds 2 and 1 (each within the scatter of the next); then compound 3.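

At this place, on an aromatic carbon of the shared core, this assay responds strongly to exchanging the whole group: 2-methyl-6-(methylcarbamoyl)pyridin-3-yl gives a 19-fold higher number from compound 2 to compound 3 (1.28 log units; beyond the scatter) and a 9.5-fold higher number from compound 1 to compound 3 (0.98 log units; beyond the scatter), both printed as beyond the scatter. Going by these compounds alone, the earlier methyl step on the five-membered ring stayed within the scatter, so this exchange is the first to show that the group at this position can move the number, and compound 3 now stands highest of the three. Nothing measured here explains what in the entering group produces the rise.

The compounds shown leave open whether the rise follows the six-membered aromatic ring, its methyl or its methylcarbamoyl group, as all three enter together. They also leave open how the number would move with an amine or a carboxylic acid in place of the methylcarbamoyl group.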